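Propylamino in place of dimethylamino on the shared core

The source may hold more compounds than are shown below. What is called first, only, known or untested is meant among the compounds shown, and "the series" means these compounds.

Among the compounds with values here, in an ADME assay on microsomes from liver (Homo sapiens) for metabolic stability, with a stated time of 10 min (on this read-out higher numbers stand for a more stable compound and lower numbers for a less stable compound), compound 2 `CN(C)[C@@H]1CC[C@H](NC(=O)CNC(=O)c2cccc(C(F)(F)F)c2)C[C@@H]1CS(=O)(=O)c1ccccc1` gives 4.4%, the lowest of the two numbers so far, while compound 1 `CCN[C@@H]1CC[C@H](NC(=O)CNC(=O)c2cccc(C(F)(F)F)c2)C[C@@H]1CS(=O)(=O)c1ccccc1` gives 24%. Compound 3 `CCCN[C@@H]1CC[C@H](NC(=O)CNC(=O)c2cccc(C(F)(F)F)c2)C[C@@H]1CS(=O)(=O)c1ccccc1` is still unmeasured. Its difference from compound 2 is propylamino in place of dimethylamino on a saturated ring carbon, with propylamino in place of dimethylamino on a saturated ring carbon. Within the data shown here, only one measured step bears on this change: a number 19.6 percentage points lower from compound 1 to compound 2 (beyond the scatter), a modest step beyond the scatter, with dimethylamino in place of ethylamino at the same place. Propylamino stands closer to ethylamino than to dimethylamino, so that step, read in reverse, offers a rough guide. Among the measured compounds shown here, no measured compound shows what the longer chain does. The expected step is a number 13.6 percentage points higher from compound 2 to compound 3 (beyond the scatter), upward and of similar modest size. For compound 3 the estimated value in this assay is 18%, within an expected range of 7% to 33%.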

Compound 3, percent of the compound remaining: 11%
Estimate against measurement, compound 3: 7 percentage points above; measured number inside the range.
By their numbers in this assay, from the lowest: compounds 2 and 3 (each within the scatter of the next); then compound 1.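

In this assay, the step of a number 6.6 percentage points higher from compound 2 to compound 3 (within the scatter) leaves propylamino and dimethylamino at this saturated ring carbon not told apart, so a secondary amine at this place does not by itself hold the number of compound 1; compound 3 goes against any such reading. The chain itself counts here: the step of a number 13 percentage points lower from compound 1 to compound 3 (beyond the scatter) shows that one added methyl on the ethylamino chain is enough to move the read-out beyond the scatter. Nothing at hand speaks to the cause of either step.

From the compounds shown here alone, whether a shorter methylamino group, a free primary amine or a branched isopropylamino group would match or pass compound 1 at 24% stays open. So does whether a longer butylamino chain would continue the step seen with propylamino.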